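The compounds below may be only part of what the source reports. "The series", "measured", "known", "first", "only" and "open" are said of these compounds alone.

Measured compounds:
compound 1, `Cc1[nH]c(=O)n(C)c1-c1ccc(CC(C)C)cc1`, 7800 nM
compound 2, `CCCCCc1ccc(-c2c(C)[nH]c(=O)n2C)cc1`, 5900 nM
compound 3, `Cc1[nH]c(=O)n(C2CCCCC2)c1-c1ccc(CC(C)C)cc1`, 10900 nM

All three were tested in a functional assay on brain (Rattus norvegicus, strain Wistar) for inhibition; on this read-out higher numbers stand for weaker inhibition and lower numbers for stronger inhibition. Compound 1 and compound 2 differ in one place only: butyl in place of isopropyl on a saturated chain carbon bound to an aromatic carbon. That change gave a 1.3-fold lower number from compound 1 to compound 2 (0.12 log units; within the scatter). Compound 3 carries a different core, the difference being (cyclohexyl in place of methyl on an aromatic nitrogen), and that change gave a 1.4-fold higher number from compound 1 to compound 3 (0.15 log units; within the scatter). Among the three, compound 3 has the highest number, but its gaps to compound 1 and to compound 2 both lie within the scatter, so no order among them can be claimed.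

Compound 4, `CCCCCc1ccc(-c2c(C)[nH]c(=O)n2C2CCCCC2)cc1`, has not yet been measured. It differs from compound 3 by butyl in place of isopropyl on a saturated chain carbon bound to an aromatic carbon, which is the same change that separates compound 1 from compound 2, now made on the core of compound 3. The step from compound 3 to compound 4 in this assay is expected to be about as small as the earlier one, roughly a 1.3-fold lower number from compound 3 to compound 4 (0.11 log units; within the scatter), because the earlier change gave only a 1.3-fold lower number from compound 1 to compound 2 (0.12 log units; within the scatter). Compound 4 is therefore estimated at 8400 nM, with a likely range from 4000 nM to 18000 nM.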

Compound 4, half-maximal inhibitory concentration: 10600 nM
For compound 4 the middle estimate is 1.3-fold (0.10 log units) below the measured one, within the range that was stated.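

In this assay, butyl in place of isopropyl on the core of compound 3 gave a 1.0-fold lower number from compound 3 to compound 4 (0.01 log units; within the scatter), a step that agrees with the one seen on the other core: the same change on two cores in this assay, a 1.3-fold lower number (0.12 log units; within the scatter) from compound 1 to compound 2 and a 1.0-fold lower number (0.01 log units; within the scatter) from compound 3 to compound 4, 1.3-fold (0.11 log units) apart, within the scatter of two such steps. Cyclohexyl in place of methyl on the aromatic nitrogen gave a 1.8-fold higher number from compound 2 to compound 4 (0.25 log units; within the scatter), and this step also agrees with its earlier counterpart: the same change on two cores in this assay, a 1.4-fold higher number (0.15 log units; within the scatter) from compound 1 to compound 3 and a 1.8-fold higher number (0.25 log units; within the scatter) from compound 2 to compound 4, 1.3-fold (0.11 log units) apart, within the scatter of two such steps. Among the compounds shown here, both changes therefore behave alike on the two cores, but every step here lies within the scatter, so the data show only that neither change measurably shifted the number on either core, not that a real effect transfers from one core to the other.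

As far as these compounds go, all four compounds carry only hydrocarbon groups at the two places varied, so it stays open whether a different group would shift the number beyond the scatter. An amine or a carboxylic acid in place of butyl would test this, and only a step of that size could show whether an effect carries across cores.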